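The source may report more compounds than this note shows. Statements on the series, on what has been measured and on what is new or still open speak of the compounds shown alone.

Measured compounds:
compound 1, `O[C@@H]1[C@H](O)CN[C@@H]1Cn1cc(-c2ccccc2)nn1` — in an assay on isolated protein for inhibition of alpha-mannosidase (Canavalia ensiformis), with stated times of 5 min and 20 min, tested at 1 mM (a higher number here means more inhibition at the concentration tested (going by the name of the read-out), a lower number less inhibition), compound 1 gives "not active" (no number reported)
compound 2, `O=C(NC[C@@H]1NC[C@@H](O)[C@H]1O)c1ccccc1` — compound 2 gives 71%
compound 3, `O[C@H]1[C@@H](O)CN[C@@H]1Cn1cc(-c2ccccc2)nn1` — compound 3 gives 60%

Compound 3 stands lowest of the two numbers reported. Its nearest neighbour is compound 2, whose result lies higher by a margin beyond the usual scatter of this assay; compound 1 has no number at all, being recorded as not active. What separates compound 1 from compound 3 is the fact that compounds 1 and 3 differ only in the configuration as drawn, so configuration alone already decides here between a measurable inhibition and none.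

Compound 4, `O[C@@H]1[C@H](O)CN[C@H]1Cn1cc(-c2ccccc2)nn1`, is the next compound to be measured. Compared with compound 3 it differs as follows: the two compounds have the same atoms and bonds and differ only in configuration as drawn: 3 of 3 stereo elements differ (all stereocentres are inverted: mirror images); a stereocentre at a saturated ring carbon is drawn R in compound 3 and S in compound 4; a stereocentre at a saturated ring carbon is drawn S in compound 3 and R in compound 4; a stereocentre at a saturated ring carbon is drawn R in compound 3 and S in compound 4. No measured pair of this kind exists among the compounds shown, so the size of the step from compound 3 to compound 4 has to be judged from compound 1 alone. Because the fact that compounds 1 and 3 differ only in the configuration as drawn is all that separates a compound reported as not active from compound 3, a change of all stereocentres is expected to lower the number in this assay, and a drop beyond the scatter in this assay is the likelier outcome. For compound 4 the expected result in this assay is therefore 20%, within a range from 0% to 55%, which corresponds to an estimated step from compound 3 to compound 4 of a number 40 percentage points lower from compound 3 to compound 4 (beyond the scatter).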

Compound 4, a percentage reported as inhibition, at one concentration (the size of the read-out at that concentration, not a potency): "not active" (no number reported)
No number was reported for compound 4, so the estimate cannot be set against anything.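

In this assay, among the compounds shown here, compound 4 gives "not active" (no number reported), so it has no number to set beside that of compound 3, and no step from compound 3 to compound 4 can be read. The compounds shown leave open how much inhibition, if any, compound 1 and compound 4 retain, and so how large the loss from compound 3 is.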